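This account rests on a few compounds, and the source may have more. Where it says the series, first, only, none or still open, it means among the compounds named here.

Compound 1, `O=[N+]([O-])c1ccc(CN2CCC(n3cc(CC(OCc4cc(-c5ccc(Br)cc5)no4)c4ccc(Br)cc4)nn3)CC2)cc1`: in a functional assay on PC-3 cells (Homo sapiens) for cytotoxicity, with a stated time of 48 h (a lower number here means a stronger inhibitor, a higher number a weaker inhibitor), compound 1 gives > 25000 nM, which is a limit of the assay rather than a number.
Compound 2, `O=[N+]([O-])c1ccc(CN2CCC(n3cc(CC(OCc4cc(-c5ccc(F)cc5)no4)c4ccc(Br)cc4)nn3)CC2)cc1`: in this assay compound 2 gives > 25000 nM, again a limit of the assay.
Compound 3, `O=[N+]([O-])c1ccc(CN2CCC(n3cc(CC(OCc4cc(-c5cccc(F)c5)no4)c4ccc(Br)cc4)nn3)CC2)cc1`: in this assay compound 3 gives 9000 nM.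

Among the measured compounds shown here, compound 3 therefore holds the only actual number among the three; the other two sit at the limit of > 25000 nM in this assay, at which 2 of the 3 values shown sit. Compound 4, `N#Cc1cccc(-c2cc(COC(Cc3cn(C4CCN(Cc5ccc([N+](=O)[O-])cc5)CC4)nn3)c3ccc(Br)cc3)on2)c1`, differs from compound 3 in one spot: cyano in place of fluoro on an aromatic carbon. The group sits on an aromatic carbon of a six-membered aromatic ring of carbon only, meta to a large group, so the change reads 3-fluorophenyl to 3-cyanophenyl. For the measured compounds named here, no measured step swaps fluoro for cyano; the steps that exist move the substituent around the ring: an at least 2.7-fold lower number from compound 1 to compound 3 (0.44 log units; beyond the scatter) and an at least 2.7-fold lower number from compound 2 to compound 3 (0.44 log units; beyond the scatter). Both favour the position that compound 4 keeps, yet they say nothing about cyano itself. Without a direct precedent, no step beyond the scatter is expected in this assay. Compound 4 is estimated at 9000 nM, with a range from 3000 nM to 25000 nM. For compound 4 this estimate means an expected no change at the digits printed from compound 3 to compound 4 (within the scatter).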

Compound 4, half-maximal inhibitory concentration: > 25000 nM
Compound 4: no number, only a limit (the forecaster's own chance of this, stated with the estimate: 30%); middle value at least 2.7-fold (0.44 log units) from the limit.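

In this assay, cyano in place of fluoro gives an at least 2.7-fold higher number from compound 3 to compound 4 (0.44 log units; beyond the scatter), and a higher number here means a weaker inhibitor. The earlier steps shown here showed only that 3-fluorophenyl gave a lower number than the 4-substituted rings, which could have been credited to the position alone; this result shows that the group at that position matters too, since 3-cyanophenyl does not keep the gain. The steps from compound 1 and compound 2 to compound 4 cannot be read, and compound 3 remains the only compound with a number rather than a limit: the limit of > 25000 nM in this assay, at which 3 of the 4 values shown sit.

As far as these compounds go, what stays open is whether fluoro is unusual at this spot or whether other groups would also give a number. A chloro, a methoxy or an amine on the same aromatic carbon would begin to answer that.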